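A few compounds are considered here, and "the series" means these few. Any claim that something is new, unique, unknown or untested is made for them only; others in the source may bear on it.

Three compounds have so far been measured in a functional assay on A-375 cells (Homo sapiens) for antiproliferative activity, read by CCK-8 assay, with a stated time of 72 h, tested at 2 uM; on this read-out lower numbers stand for a weaker effect and higher numbers for a stronger effect at the one concentration tested:

Compound 1 `Nc1ccccc1NC(=O)c1ccc(CSC(=S)N2CCN(c3ccc(Cl)cc3)CC2)cc1` gives 32.2%.
Compound 2 `Nc1ccccc1NC(=O)c1ccc(CSC(=S)N2CCc3cc([N+](=O)[O-])ccc32)cc1` gives 16.9%.
Compound 3 `CN(Cc1cccnc1)C(=S)SCc1ccc(C(=O)Nc2ccccc2N)cc1` gives 39.4%.

Among these three numbers compound 1 stands second highest. Its reading and that of compound 3 are close enough to fall within the usual scatter of repeated measurements, so no order between the two can be claimed. Compound 2, by contrast, lies beyond the scatter below compound 1, so on these numbers it is the weaker of that pair.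

The next compound, compound 4 `Nc1ccccc1NC(=O)c1ccc(CSC(=S)N2CCN(c3ncccn3)CC2)cc1`, has not yet been measured in this assay. It differs from compound 1 in one place: pyrimidin-2-yl in place of 4-chlorophenyl on an amine nitrogen in a ring. All other parts of the molecule, including the shared core, are unchanged.

Among the compounds with values here, no measured pair here shows the effect of such a change, so the size and direction of the step are open. On this basis the expectation is a step from compound 1 to compound 4 of a number 5.2 percentage points lower from compound 1 to compound 4 (within the scatter), that is, a shift no larger than the scatter, if anything slightly downward. Compound 4 is therefore estimated to give 27% in this assay, with a plausible range from 12% to 42%.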

Compound 4, a percentage reported as inhibition, at one concentration (the size of the read-out at that concentration, not a potency): 24%
Compound 4: middle estimate off by 3 percentage points, on the high side; the range from low to high includes it.
By their numbers in this assay, from the lowest: compounds 2, 4, 1 and 3 (each within the scatter of the next, the first and the last beyond it).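

Within the data shown here, the change from 4-chlorophenyl to pyrimidin-2-yl on the amine nitrogen gives the first direct reading at this position in this assay, a step of a number 8.2 percentage points lower from compound 1 to compound 4 (within the scatter) for this one change. With the rest of the molecule unchanged, the step gives no order between the two compounds: a six-membered aromatic ring of carbon only and one with 2 hetero atoms cannot be told apart here, although the entering group adds 2 hydrogen-bond acceptors and the leaving group has none. No outside measurement is available to explain this result.

From the compounds shown here alone, both groups compared at this nitrogen are six-membered aromatic rings, so it remains open whether a pyridin-2-yl group, a plain methyl group or an acetyl group there would give a reading that differs by more than the usual scatter. Going by these compounds, each reading in this assay also comes from a single concentration, so the effect of this change on potency remains open as well.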